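A few compounds are considered here, and "the series" means these few. Any claim that something is new, unique, unknown or untested is made for them only; others in the source may bear on it.

In a functional assay on LNCaP cells (Homo sapiens) for antiproliferative activity, read by propidium iodide staining, with a stated time of 96 h (a lower number here means a stronger inhibitor, a higher number a weaker inhibitor), compound 1 `CC(O)(COc1cccc(C(F)(F)F)c1)C(=O)Nc1ccc(S(F)(F)(F)(F)F)cc1` gives 24700 nM, compound 2 `CC(O)(COc1cccc(OC(F)(F)F)c1)C(=O)Nc1ccc(S(F)(F)(F)(F)F)cc1` gives 11000 nM, and compound 3 `CC(O)(COc1ccc(C(F)(F)F)cc1)C(=O)Nc1cccc(S(F)(F)(F)(F)F)c1` gives 9600 nM. Compound 1 and compound 3 contain the same atoms joined differently; the difference between the two cores is not broken down here. From compound 1 to compound 2 the change is trifluoromethoxy in place of trifluoromethyl on an aromatic carbon, and it gave a 2.2-fold lower number from compound 1 to compound 2 (0.35 log units; beyond the scatter). Compound 4 `CC(O)(COc1ccc(OC(F)(F)F)cc1)C(=O)Nc1cccc(S(F)(F)(F)(F)F)c1` has not been measured. It differs from compound 3 by trifluoromethoxy in place of trifluoromethyl on an aromatic carbon, the same kind of change as before, though here the group sits para to a large group, whereas in compound 2 it sits meta to a large group. Because a 2.2-fold lower number from compound 1 to compound 2 (0.35 log units; beyond the scatter), a step of similar size is expected for compound 4, namely a 1.7-fold lower number from compound 3 to compound 4 (0.24 log units; within the scatter). Compound 4 is therefore estimated at 5500 nM, with a range from 2200 nM to 14000 nM.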

Compound 4, half-maximal inhibitory concentration: 12700 nM
Beside the measured number, compound 4's estimate is 2.3-fold (0.36 log units) below it; measured number inside the range.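

In this assay, the effect of trifluoromethoxy in place of trifluoromethyl did not carry over from one core to the other: the same change on two cores in this assay, a 2.2-fold lower number (0.35 log units; beyond the scatter) from compound 1 to compound 2 and a 1.3-fold higher number (0.12 log units; within the scatter) from compound 3 to compound 4, 3.0-fold (0.47 log units) apart, beyond the scatter of two such steps. On the core of compound 3, the change gave a 1.3-fold higher number from compound 3 to compound 4 (0.12 log units; within the scatter), so the earlier gain did not recur there. The two cores differ in more than one place, and these two pairs show neither which difference matters nor how the change would behave on any further core.

The compounds shown leave open how a nitrile or a methoxy group would compare at the same aromatic carbon. They also leave open whether an amine in place of the hydroxyl on the shared chain would alter the number.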